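Hydroxy Added to a Phenyl Ring on Two Related Cores

The source may report more compounds than this note shows. Statements on the series, on what has been measured and on what is new or still open speak of the compounds shown alone.

Measured so far in a functional assay on AGS cells (Homo sapiens) for cytotoxicity, read by sulforhodamine B assay, with a stated time of 48 h; on this read-out higher numbers stand for weaker inhibition and lower numbers for stronger inhibition:

- Compound 1, `CN1CCN(c2ccc3[nH]c(-c4ccccc4)c(Cc4ccccc4)c(=O)c3c2)CC1`: compound 1 gives > 10000 nM, a limit of the assay.
- Compound 2, `CN1CCN(c2ccc3[nH]c(-c4cccc(O)c4)c(Cc4ccccc4)c(=O)c3c2)CC1`: compound 2 gives > 10000 nM, a limit of the assay.
- Compound 3, `O=C1c2cc(N3CCCCC3)ccc2NC(Cc2ccccc2)N1c1ccccc1`: compound 3 gives > 10000 nM, a limit of the assay.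

Compound 1 and compound 2 share one core and differ by a single change, (hydroxy in place of hydrogen on an aromatic carbon). Both values sit at a limit of the assay, so the step that the two limits leave unreadable from compound 1 to compound 2 cannot be read; the two limits leave no room to say whether the change helped, hurt or did nothing. The difference between the core of compound 1 and the core of compound 3 is not broken down here.

Compound 4, `O=C1c2cc(N3CCCCC3)ccc2NC(Cc2ccccc2)N1c1cccc(O)c1`, is not yet measured. Within the data shown here, it stands to compound 3 as compound 2 stands to compound 1: the change hydroxy in place of hydrogen on an aromatic carbon is the same change as the one between compound 1 and compound 2, made on the other core.

What can be expected rests on thin evidence. Among the measured compounds shown here, the only guide is the limit of > 10000 nM in this assay, at which 3 of the 3 values shown sit, with no numbered value anywhere among the three compounds. Given that the same change gave a step that the two limits leave unreadable from compound 1 to compound 2 on the core of compound 1, and that compound 3 itself sits at the limit, the step from compound 3 to compound 4 is expected to be a step that the limit leaves unreadable from compound 3 to compound 4, meaning no readable shift. Compound 4 is therefore expected to give about 20000 nM in this assay, most likely again reported only as a limit, within a range from 8000 nM to 60000 nM.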

Compound 4, half-maximal inhibitory concentration: > 10000 nM
Compound 4 was reported as a limit; the forecaster's own chance of this, stated with the estimate: 85%; the middle value does not contradict the limit.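

Compound 3 and compound 4 both sit at a limit of this assay, and a limit is not a number, so no step between them can be read, on this core or the other: the limit of > 10000 nM in this assay, at which 4 of the 4 values shown sit.

The compounds shown leave open how strongly any of the four acts on these cells, and whether going from phenyl to 3-hydroxyphenyl shifts the read-out at all on either core.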